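The compounds below may be only part of what the source reports. "The series", "measured", "known", "first", "only" and "open" are said of these compounds alone.

Among the measured compounds shown here, compound 3 `CN(C[C@@H]1CCCc2cc(S(=O)(=O)c3cccc(F)c3)ccc21)S(N)(=O)=O` stands highest of the three numbers so far in an assay on isolated protein for displacement of a labelled ligand from 5-hydroxytryptamine receptor 6 (Homo sapiens); a higher number here means a weaker inhibitor, a lower number a stronger inhibitor. Compound 1 `NC[C@@H]1CCCc2cc(S(=O)(=O)c3cccc(O)c3)ccc21` gives 0.251 nM, compound 2 `COc1cccc(S(=O)(=O)c2ccc3c(c2)CCC[C@H]3CN)c1` gives 0.398 nM, and compound 3 gives 3.98 nM. For the measured compounds named here, the only step between measured compounds that differ in one place is a 1.6-fold higher number from compound 1 to compound 2 (0.20 log units; within the scatter), a change on an oxygen on an aromatic ring, and it does not bear on the position now in question. Going by the values given here, compounds 1 and 2 differ from compound 3 in two places at once, so their values show only that the two compounds with the free aminomethyl chain sit well below compound 3, without separating the two changes.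

Compound 4 `O=C(NC[C@@H]1CCCc2cc(S(=O)(=O)c3cccc(F)c3)ccc21)[C@H]1CCCN1` is made from compound 3 by ((pyrrolidin-2-yl)carbonyl)amino in place of methyl(sulfamoyl)amino on a saturated chain carbon bound to a saturated ring carbon. Among the compounds with values here, no measured step follows a change on this saturated chain carbon, so no step size can be read across, and the expectation for compound 4 in this assay is anchored on compound 3 with a wide spread. The step from compound 3 to compound 4 is therefore expected to be about a 1.3-fold lower number from compound 3 to compound 4 (0.12 log units; within the scatter), with no direction claimed beyond the scatter. Compound 4 is accordingly estimated at 3 nM in this assay, in a range from 0.6 nM to 15 nM.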

Compound 4, inhibition constant: 0.631 nM
The estimate for compound 4 lay 4.8-fold (0.68 log units) above the measured number; the measured number falls inside the stated range.
By their numbers in this assay, from the lowest: compounds 1, 2 and 4 (each within the scatter of the next, the first and the last beyond it); then compound 3.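

In this assay, the saturated chain carbon bound to a saturated ring carbon is shown for the first time to be a place where a single change moves the number beyond the scatter: a 6.3-fold lower number from compound 3 to compound 4 (0.80 log units; beyond the scatter). Among the compounds shown here, the only earlier single-place step lay on an oxygen on an aromatic ring, so it said nothing about this position. Here, ((pyrrolidin-2-yl)carbonyl)amino, with 8 heavy atoms and a five-membered non-aromatic ring, goes with a lower number than methyl(sulfamoyl)amino, with 6 heavy atoms, so the larger group carries no penalty in this one pair, and no measurement at hand gives a reason for the step.

The change replaces the sulfamoyl group, the methyl and the ring-free chain end in a single move, so the compounds shown cannot assign the step to any one of these parts. On these data alone, it remains open how an acetyl amide, an open-chain aminoacetyl group or a piperidine-2-carbonyl group would stand at this position, and how the opposite configuration of the pyrrolidine stereocentre would read.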